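Aryl sulfonamide series: antiproliferative activity in DLD-1 cells

The source may hold more compounds than are shown below. What is called first, only, known or untested is meant among the compounds shown, and "the series" means these compounds.

Measured compounds:
- compound 1, `Cc1c(C)c(S(=O)(=O)N2CCC(N3CCC(C)CC3)CC2)c(C)c2c1OC(C)(C)C2`: 1.2 nM
- compound 2, `CC1CCN(C2CCN(S(=O)(=O)c3cccc(-c4ccc5ccccc5c4)c3)CC2)CC1`: 2 nM
- compound 3, `CC1CCN(C2CCN(S(=O)(=O)c3ccccc3-c3ccccc3)CC2)CC1`: 0.96 nM

In a functional assay on DLD-1 cells (Homo sapiens) for antiproliferative activity, read by CellTiter-Glo, with a stated time of 72 h (a higher number here means a weaker inhibitor, a lower number a stronger inhibitor), compound 2 gives 2 nM, the highest of the three numbers. Its nearest neighbour is compound 1, whose value of 1.2 nM lies within the scatter of compound 2, so no order between these two can be read. For the measured compounds named here, compound 3, at 0.96 nM, sits beyond the scatter below compound 2 and is the one measured compound separated from it. All three values fall in a narrow band, and the three compounds share the same sulfonamide-linked piperidinylpiperidine portion, differing only in the aryl part.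

The step to compound 4, `Cc1ccc(-c2cccc(S(=O)(=O)N3CCC(N4CCC(C)CC4)CC3)c2)cc1`, alters that aryl part: 4-methylphenyl in place of naphthalen-2-yl on an aromatic carbon The change sits on an aromatic carbon, meta to a large group, and both the leaving and the entering groups are hydrocarbon aromatics without donors or acceptors. Given that compounds 1 to 3 with quite different aryl groups all lie close together in this assay, no step beyond the scatter is expected from compound 2 to compound 4; the estimated step is a 1.3-fold lower number from compound 2 to compound 4 (0.12 log units; within the scatter). Compound 4 is expected to give about 1.5 nM in this assay, in the range 0.6 nM to 4 nM.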

Compound 4, half-maximal inhibitory concentration: 11 nM
Compound 4: the middle estimate sits 7.3-fold (0.87 log units) below what was measured; the whole stated range lies below it.
By their numbers in this assay, from the lowest: compounds 3, 1 and 2 (each within the scatter of the next, the first and the last beyond it); then compound 4.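

In this assay, 4-methylphenyl in place of naphthalen-2-yl on an aromatic carbon, meta to a large group, gives a 5.5-fold higher number from compound 2 to compound 4 (0.74 log units; beyond the scatter), so the aryl group at this position can move the number beyond the scatter. This holds even though the leaving and entering groups both consist of carbon-only aromatic rings, with no hydrogen-bond donors or acceptors and no net charge. Compounds 1 to 3 differ in more than one place, so their close numbers gave no direct reading of this position, and the narrow band they form cannot be taken as tolerance of any aryl group there. Nothing shown here accounts for the step.

The step combines two differences, since the entering group has one aromatic ring where the leaving group has two and also carries a methyl group, and a single pair of compounds cannot separate them. An unsubstituted phenyl or a 4-chlorophenyl at the same aromatic carbon would help to show which of the two differences goes with the higher number, and whether other groups at this place follow it.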